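This account rests on a few compounds, and the source may have more. Where it says the series, first, only, none or still open, it means among the compounds named here.

In a functional assay on the whole organism (strain Kunming) with Mus musculus as the target, with a stated time of 0.5 h (on this read-out lower numbers stand for an effect already at smaller amounts and higher numbers for an effect only at larger amounts of compound), three compounds sharing one core have been measured. Compound 1 `COc1cc(OC)c(OC)cc1/C=C/COC(=O)/C=C/c1cc(OC)c(OC)c(OC)c1OC` gives 30.9 mg/kg, compound 3 `COc1cc(OC)c(OC)cc1/C=C/COC(=O)/C=C/c1ccc(OC)c(OC)c1OC` gives 33.4 mg/kg, and compound 2 `COc1cc(OC)c(OC)cc1/C=C/COC(=O)/C=C/c1ccccc1C(F)(F)F` gives 85.7 mg/kg, the highest of the three numbers and beyond the scatter from both others. Compound 4 `COc1ccc(/C=C/C(=O)OC/C=C/c2cc(OC)c(OC)cc2OC)cc1` differs from compound 2 in one place: 4-methoxyphenyl in place of 2-(trifluoromethyl)phenyl on a double-bonded chain carbon bound to a double-bonded chain carbon. Among the measured compounds shown here, the only measured step, a 1.1-fold higher number from compound 1 to compound 3 (0.03 log units; within the scatter), puts hydrogen in place of methoxy on an aromatic carbon and stays within the scatter. It never involves trifluoromethyl, so it is only indirect evidence. Still, compound 3 carries methoxy groups in that place and gives 33.4 mg/kg, so a lower number is expected. The estimated change is a 2.0-fold lower number from compound 2 to compound 4 (0.31 log units; beyond the scatter). For compound 4 the estimated value is 42 mg/kg, with a range of 21 mg/kg to 85 mg/kg.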

Compound 4, dose for half-maximal effect: 70.6 mg/kg
Compound 4: middle estimate off by 1.7-fold (0.23 log units), on the low side, within the range that was stated.
By their numbers in this assay, from the lowest: compounds 1 and 3 (each within the scatter of the next); then compounds 4 and 2 (each within the scatter of the next).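

In this assay, putting 4-methoxyphenyl in place of 2-(trifluoromethyl)phenyl gives a 1.2-fold lower number from compound 2 to compound 4 (0.08 log units; within the scatter), so at this position the two groups cannot be told apart. A single methoxy group entering here is therefore not enough on its own to move the number beyond the scatter, which the earlier step could not show. Nothing measured here offers an explanation for this result. Still open, as far as these compounds go, is whether a phenyl ring carrying an amine or a carboxylic acid at this place would shift the number.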